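This account rests on a few compounds, and the source may have more. Where it says the series, first, only, none or still open, it means among the compounds named here.

Measured so far in an ADME assay on 184B5 cells (Homo sapiens) for cytotoxicity, read by MTT assay, with a stated time of 72 h; a higher number here means a weaker inhibitor of growth, a lower number a stronger inhibitor of growth:
compound 1, `CC(C)COC(=O)Nc1ccc([Se][Se]c2ccc(NC(=O)OCC(C)C)cc2)cc1`, 10500 nM;
compound 2, `N#C[Se]c1ccc(NC(=O)Oc2ccc(F)cc2)cc1`, 29500 nM;
compound 3, `CCOC(=O)Nc1ccc([Se]C#N)cc1`, 18600 nM.

Among these three numbers compound 2 carries the highest one, yet its standing is mixed: its number and that of compound 3 lie within the scatter of each other, so nothing separates them, whereas the gap from compound 2 to compound 1 goes beyond the scatter, compound 1 giving the lower number of the two.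

The next compound, compound 4, is `N#C[Se]c1ccc(NC(=O)Oc2ccc(Cl)cc2)cc1`. It differs from compound 2 in one place, (chloro in place of fluoro on an aromatic carbon). Going by the values given here, no measured pair here carries this same change, so nothing in the data fixes the size of the step. Since compound 2 gives 29500 nM and a halogen swap of this kind gives no guidance from the present set, the expectation is a step of a 1.2-fold lower number from compound 2 to compound 4 (0.07 log units; within the scatter), essentially none beyond the scatter. Compound 4 is therefore estimated at 25000 nM in this assay, with a range from 10000 nM to 65000 nM.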

Compound 4, concentration for total growth inhibition: 19900 nM
Estimate against measurement, compound 4: 1.3-fold (0.10 log units) above, within the range that was stated.
By their numbers in this assay, from the lowest: compounds 1, 3, 4 and 2 (each within the scatter of the next, the first and the last beyond it).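

In this assay, going by these compounds alone, the change of chloro in place of fluoro, on an aromatic carbon para to a large group, gives a 1.5-fold lower number from compound 2 to compound 4 (0.17 log units; within the scatter) and so provides the first step between compounds that differ in one place. Within the data shown here, at this position, the exchange of one halogen for the other does not separate the two compounds, something the earlier compounds could not show because no two of them formed such a pair. Nothing available bears on why this step has the size it has.

The compounds shown leave open whether a bromo, a methoxy or an amine on this same aromatic carbon would give a step beyond the scatter. They also leave open whether chloro in place of fluoro would give a similar step in another compound.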